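Furan to Thiophene on a Shared Nucleoside Core

This account rests on a few compounds, and the source may have more. Where it says the series, first, only, none or still open, it means among the compounds named here.

Measured compounds:
compound 1, `Cc1nc(N)c2c(-c3cccs3)cn([C@@H]3O[C@H](CO)[C@@H](O)[C@H]3O)c2n1`: > 20000 nM
compound 2, `Cc1nc(N)c2c(-c3ccco3)cn([C@@H]3O[C@H](CO)[C@@H](O)[C@H]3O)c2n1`: > 20000 nM
compound 3, `Nc1nc2c(c(-c3ccco3)cn2[C@@H]2O[C@H](CO)[C@@H](O)[C@H]2O)c(=O)[nH]1`: > 20000 nM

In a functional assay on K562 cells (Homo sapiens), read by MTT assay, with a stated time of 72 h (a lower number here means a stronger inhibitor, a higher number a weaker inhibitor), compound 1 gives > 20000 nM, which is a limit of the assay and not a number. Compound 2 likewise gives > 20000 nM, again a limit. Compound 3 gives > 20000 nM, also a limit. Compound 1 and compound 2 share one core and differ in one place: thiophen-2-yl in place of furan-2-yl on an aromatic carbon. The step that the two limits leave unreadable from compound 2 to compound 1 cannot be read, since both values are limits. Compound 3 carries a different core; the difference between the two cores is not broken down here. All three measured values sit at the same point, as the evidence the limit of > 20000 nM in this assay, at which 3 of the 3 values shown sit, shows.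

Compound 4, `Nc1nc2c(c(-c3cccs3)cn2[C@@H]2O[C@H](CO)[C@@H](O)[C@H]2O)c(=O)[nH]1`, has not yet been tested. It differs from compound 3 in one place: thiophen-2-yl in place of furan-2-yl on an aromatic carbon. The place described is the same, word for word, as in the pair of compound 2 and compound 1, so this is the same change made on the other core.

The step from compound 3 to compound 4 in this assay is expected to be a step that the limit leaves unreadable from compound 3 to compound 4, which rests on the fact that the same change between compound 2 and compound 1 left both values at the limit (the limit of > 20000 nM in this assay, at which 3 of the 3 values shown sit). Compound 4 is therefore expected to give about 30000 nM. For compound 4 the expected range runs from 20000 nM to 100000 nM, and most likely only a limit will be reported.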

Compound 4, half-maximal inhibitory concentration: 16800 nM
Beside the measured number, compound 4's estimate is 1.8-fold (0.25 log units) above it; the whole stated range lies above it.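

In this assay, putting thiophen-2-yl in place of furan-2-yl on the core of compound 3 gives an at least 1.1-fold lower number from compound 3 to compound 4 (0.07 log units; that floor lies within the scatter), and the floor on this step is too small to show a real change. Going by these compounds alone, compound 4, at 16800 nM, is the only one of the four compounds with a value that is an actual number; this shows that the thiophen-2-yl compound on this core falls inside the range the assay can read. Compound 3 gives > 20000 nM, which is a limit of the assay and not a number, so the true size of the step could be close to that small floor or much larger. The same change on the other core, from compound 2 to compound 1, cannot be read, so there is no second size to set against the first, and the result does not show whether the change carries over from one core to the other: the limit of > 20000 nM in this assay, at which 3 of the 4 values shown sit.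

The compounds shown leave open what a different group on the same aromatic carbon, such as a phenyl ring or an amine, would give on either core. They also leave open whether any such group would bring a value well clear of the limit, which would make a step between compounds fully readable.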